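The source may hold more compounds than are shown below. What is called first, only, known or untested is meant among the compounds shown, and "the series" means these compounds.

Two compounds share one core and differ only in a single group attached to an aromatic carbon. Compound 1 `C=C[C@@H]1OC(c2ccc(Cl)cc2)=N[C@H]1CO` carries a chloro group there; in an assay on isolated protein for inhibition of matrix metalloproteinase-9 (Homo sapiens) (on this read-out higher numbers stand for weaker inhibition and lower numbers for stronger inhibition), compound 1 gives 33000 nM. Compound 2 `C=C[C@@H]1OC(c2ccc(Oc3ccccc3)cc2)=N[C@H]1CO` carries a phenoxy group in the same place; in this assay compound 2 gives 32000 nM. The step of a 1.0-fold lower number from compound 1 to compound 2 (0.01 log units; within the scatter) shows that exchanging these two groups left the read-out essentially unchanged, so the numbers for compound 2 and compound 1 sit within the scatter of each other. Compound 3 `C=C[C@@H]1OC(c2ccc(C)cc2)=N[C@H]1CO` has not been measured. Its difference from compound 2 is methyl in place of phenoxy on an aromatic carbon. Within the data shown here, the only measured step that bears on this change is a 1.0-fold lower number from compound 1 to compound 2 (0.01 log units; within the scatter), and it stayed within the scatter, so another swap of the same group is expected to move this assay little: the expected step is a 1.0-fold higher number from compound 2 to compound 3 (0.01 log units; within the scatter). Compound 3 is therefore expected to give about 33000 nM, within a range from 12000 nM to 90000 nM.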

Compound 3, inhibition constant: 68000 nM
The estimate for compound 3 lay 2.1-fold (0.31 log units) below the measured number; low and high end bracket the measured number.
By their numbers in this assay, from the lowest: compounds 2 and 1 (each within the scatter of the next); then compound 3.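

The group on this aromatic carbon can shift the read-out after all: in this assay methyl in place of phenoxy gives a 2.1-fold higher number from compound 2 to compound 3 (0.33 log units; beyond the scatter) and methyl in place of chloro gives a 2.1-fold higher number from compound 1 to compound 3 (0.31 log units; beyond the scatter) as a modest change, which leaves compound 3 the weakest inhibitor of the three. The read-out does not simply track how large the group is, since phenoxy, with its 7 heavy atoms and aromatic ring, and the much smaller chloro stay within the scatter of each other while methyl stands apart from both. No measurement shown here explains why methyl differs from the other two groups.

Going by these compounds, whether an amine, a carboxylic acid or a longer chain in this place would give a lower or a higher number remains open. So does whether any group here could bring a large change rather than a modest one.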